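Swapping an Amide-Bearing Side Chain for an Ester

The source may hold more compounds than are shown below. What is called first, only, known or untested is meant among the compounds shown, and "the series" means these compounds.

Measured compounds in an assay on isolated protein (strain Sprague-Dawley) for inhibition of Amine oxidase [flavin-containing] B (Rattus norvegicus), read by spectrophotometry, with a stated time of 5 min; a lower number here means a stronger inhibitor, a higher number a weaker inhibitor:
Compound 1 `CCCOc1cc(=O)oc2cc(OCc3ccccc3)ccc12` gives 575 nM
Compound 2 `CCOc1cc(=O)oc2cc(OCc3cccc(F)c3)ccc12` gives 263 nM
Compound 3 `CN(C)C(=O)COc1cc(=O)oc2cc(OCc3cccc(Cl)c3)ccc12` gives 501 nM

The three measured compounds share one core and differ in the group on the aromatic carbon opposite the ring oxygen and in the halogen on the benzyl ring. Compound 3 stands at the second highest of the three numbers in this assay, yet its neighbours sit close: compound 1 lies within the usual scatter of it, and so does compound 2, so no order among the three can be read with confidence.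

Compound 4 `CCOC(=O)c1cc(=O)oc2cc(OCc3cccc(Cl)c3)ccc12` has not yet been measured. It differs from compound 3 in one place: ethoxycarbonyl in place of (dimethylcarbamoyl)methoxy on an aromatic carbon. The group that leaves carries an amide and an ether oxygen, the group that enters carries an ester; both bring two hydrogen-bond acceptors and no donor.

Within the data shown here, no step between two measured compounds shows what such a swap does. The measured set only shows that changes at this position among compounds 1, 2 and 3 move the number little. Compound 4 is therefore expected to stay close to compound 3, with a step of a 1.3-fold lower number from compound 3 to compound 4 (0.10 log units; within the scatter) that could fall in either direction and need not exceed the scatter. The estimate for compound 4 in this assay is 400 nM, within a range from 150 nM to 1300 nM.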

Compound 4, half-maximal inhibitory concentration: 417 nM
Compound 4: the middle estimate sits 1.0-fold (0.02 log units) below what was measured; low and high end bracket the measured number.
By their numbers in this assay, from the lowest: compounds 2, 4, 3 and 1 (each within the scatter of the next, the first and the last beyond it).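

In this assay, among these compounds, ethoxycarbonyl in place of (dimethylcarbamoyl)methoxy on an aromatic carbon, opposite the ring oxygen, gives a 1.2-fold lower number from compound 3 to compound 4 (0.08 log units; within the scatter), and this is the only step in the set in which a single place changes. With the rest of the molecule held fixed, the amide nitrogen and the ether oxygen of the leaving group can therefore be given up for an ester with fewer heavy atoms and no change beyond the scatter, although the two groups carry the same counts of hydrogen-bond donors and acceptors, so this pair does not test a change in those counts. Nothing measured on these compounds offers an explanation for this result.

The compounds shown leave open whether an amine, a carboxylic acid or a longer ester chain in this place would move the number beyond the scatter, as both groups compared here have no net charge and no ring. They also leave open whether the same swap would give a similarly small step with the unsubstituted benzyl group of compound 1 or the fluorine-bearing benzyl group of compound 2 in place of the chlorine-bearing one.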